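This account rests on a few compounds, and the source may have more. Where it says the series, first, only, none or still open, it means among the compounds named here.

Working notes on the series in a functional assay on A549 cells (Homo sapiens) for inhibition; a higher number here means a weaker inhibitor, a lower number a stronger inhibitor. Compound 1 `COc1cc(/C=C\c2ccc(N(C)C)c([N+](=O)[O-])c2)cc(OC)c1OC` gives no number, only the assay limit of > 5000 nM. Going by the values given here, compound 2 `COc1cc(/C=C/c2ccc(N(C)C)c(N)c2)cc(OC)c1OC` gives 1520 nM, the only actual number so far. Compound 3 `COc1cc(/C=C\c2ccc(N(C)C)c(N)c2)cc(OC)c1OC` differs from compound 2 as follows: the two compounds have the same atoms and bonds and differ only in configuration as drawn: 1 of 1 stereo elements differ; a double bond is drawn E in compound 2 and Z in compound 3. Among the compounds with values here, no measured step yet sizes this change, so the expectation rests on the change alone and remains uncertain. A large shift toward stronger inhibition, well beyond the scatter, is expected, with the estimated step of a 25-fold lower number from compound 2 to compound 3 (1.40 log units; beyond the scatter). For compound 3 the estimated value is 60 nM, with an expected range of 8 nM to 900 nM.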

Compound 3, half-maximal inhibitory concentration: 4 nM
Compound 3: the middle estimate sits 15-fold (1.18 log units) above what was measured; measured number below the stated range.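

In this assay, the double bond drawn Z rather than E gives a 380-fold lower number from compound 2 to compound 3 (2.58 log units; beyond the scatter), so configuration alone carries a large step in this series: the fact that compounds 2 and 3 differ only in the configuration as drawn. With the Z double bond held, amino in place of nitro on an aromatic carbon gives an at least 1200-fold lower number from compound 1 to compound 3 (3.09 log units; beyond the scatter). Compound 1 gives only a limit, so that step has an open end: the limit of > 5000 nM in this assay, at which 1 of the 3 values shown sits.

As far as these compounds go, whether a hydroxyl or an acetamide on that aromatic carbon would keep the number of compound 3 remains open. The configuration step is also sized only with the amino group present.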